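This account rests on a few compounds, and the source may have more. Where it says the series, first, only, none or still open, it means among the compounds named here.

Among the measured compounds shown here, compound 2 `O=C(Nc1cc(C(F)(F)F)cc(C(F)(F)F)c1)C1CCc2ccccc2N1C(=O)c1ccc(Cl)cc1` is one of three compounds measured in a functional assay on NUGC-3 cells (Homo sapiens) for cytotoxicity, read by sulforhodamine B assay, with a stated time of 72 h; on this read-out lower numbers stand for stronger inhibition of growth and higher numbers for weaker inhibition of growth. In this assay compound 2 gives 1660 nM, the second-highest number of the three. The nearest neighbour on the numbers is compound 1 `O=C(Nc1ccccc1C(F)(F)F)C1CCc2ccccc2N1C(=O)c1cccc(Cl)c1`, which in this assay gives 754 nM, a lower number and a gap beyond the usual scatter. The furthest is compound 3 `CCCCCCCCC(=O)N1c2ccccc2CCC1C(=O)Nc1ccccc1O`, which in this assay gives 31100 nM, a far higher number and a gap well beyond the scatter.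

The step from compound 2 leads to compound 4 `O=C(Nc1cc(C(F)(F)F)cc(C(F)(F)F)c1)C1CCc2ccccc2N1C(=O)c1ccccc1`, which has not yet been measured. The change is hydrogen in place of chloro on an aromatic carbon, on an aromatic carbon of a six-membered aromatic ring of carbon only, para to a large group; read one bond further out, a 4-chlorophenyl becomes a phenyl. For the measured compounds named here, no pair of measured compounds shows this change, so nothing measured here tells how large its effect is.

With the chloro gone, a modest rise in number is expected, of a size that may not exceed the scatter, which is what a 1.6-fold higher number from compound 2 to compound 4 (0.19 log units; within the scatter) expresses. In this assay compound 4 is therefore estimated at 2600 nM, with a range from 1000 nM to 7000 nM.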

Compound 4, concentration for 50% growth inhibition: 1680 nM
The estimate for compound 4 lay 1.5-fold (0.19 log units) above the measured number, within the range that was stated.
By their numbers in this assay, from the lowest: compound 1; then compounds 2 and 4 (each within the scatter of the next); then compound 3.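

In this assay, hydrogen in place of chloro on an aromatic carbon, para to a large group, gives a 1.0-fold higher number from compound 2 to compound 4 (0.01 log units; within the scatter), and this is the first direct reading of this change among the compounds shown. With the rest of the structure held constant, the 4-chlorophenyl and the phenyl cannot be told apart on this read-out, so in this setting the chloro is not required for the level of growth inhibition that compound 2 shows. What lies behind this result cannot be said, as nothing given here bears on it.

The compounds shown compare only chloro and hydrogen at this place, so it remains open whether a different group there, such as a methoxy, an amine or a carboxylic acid, would shift the number beyond the scatter. From the compounds shown here alone, it also remains open whether hydrogen in place of chloro would read the same if the trifluoromethyl groups of compound 2 were replaced by another group, such as a hydroxyl or an amine.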